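This account rests on a few compounds, and the source may have more. Where it says the series, first, only, none or still open, it means among the compounds named here.

In an ADME assay on MT4 cells (Homo sapiens) for cytotoxicity, read by MTT assay, with a stated time of 5 days (on this read-out higher numbers stand for lower toxicity in this test and lower numbers for higher toxicity in this test), compound 2 `N#Cc1ccc(Nc2nccc(OCC(=O)Nc3cccc(Cl)c3)n2)cc1` stands only at a limit, > 329000 nM. Compound 1 `N#Cc1ccc(Nc2nccc(OCC(=O)Nc3ccc(F)cc3)n2)cc1` also gives only a limit, > 344000 nM. Compound 3 `N#Cc1ccc(Nc2nccc(OCC(=O)Nc3ccc([N+](=O)[O-])cc3)n2)cc1` differs from compound 2 by 4-nitrophenyl in place of 3-chlorophenyl on an amide-type nitrogen, with 4-nitrophenyl in place of 3-chlorophenyl on an amide-type nitrogen. Going by the values given here, the one measured step at this place is a step that the two limits leave unreadable from compound 1 to compound 2, so it offers no size to carry over. With nothing pointing either way, the expected change is an at least 1.1-fold lower number from compound 2 to compound 3 (0.07 log units; that floor lies within the scatter), which means no shift beyond the usual scatter in this assay. The estimate for compound 3 is 280000 nM, within an expected range from 70000 nM to 400000 nM.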

Compound 3, half-maximal cytotoxic concentration: > 320000 nM
Compound 3 ended at the assay's limit; the forecaster's own chance of this, stated with the estimate: 65%; at least 1.1-fold (0.05 log units) between middle value and limit.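

Going by these compounds alone, compound 1, compound 2 and compound 3 all give only limits in this assay, so no step among them can be read. The compounds shown leave open whether changing the aryl group on the amide nitrogen alters this read-out at all.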